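Permeability notes: tetrafluorophenyl to trifluorophenyl on the butoxy tail

The source may hold more compounds than are shown below. What is called first, only, known or untested is meant among the compounds shown, and "the series" means these compounds.

Measured in a physicochemical assay for permeability, using PAMPA, with a stated time of 4 h, at pH 7.4, tested at 50 uM; a higher number here means that the compound crosses the layer faster, a lower number that the compound crosses the layer more slowly:
Compound 1 `Cc1c(CCCC(=O)O)c2cccc(/C=C/c3ccc(OCCCCc4c(F)c(F)cc(F)c4F)cc3)c2n1CC(=O)O` gives 0.5 10^-6 cm/s.
Compound 2 `Cc1c(F)cccc1CCCCOc1ccc(C#Cc2cccc3c(CCCC(=O)O)c(C)n(CCCC(=O)O)c23)cc1` gives 12.4 10^-6 cm/s.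
Compound 3 `Cc1c(Cl)cccc1CCCCOc1ccc(C#Cc2cccc3c(CC(=O)O)c(C)n(CC(=O)O)c23)cc1` gives < 0.05 10^-6 cm/s, which is a limit of this assay and not a number.

Of the two numbers, compound 1 stands lowest; compound 2 sits well above it, beyond the scatter. Among the compounds with values here, no pair of measured compounds differs in one place, so no measured step is available.

Compound 4 `Cc1c(CCCC(=O)O)c2cccc(/C=C/c3ccc(OCCCCc4c(F)ccc(F)c4F)cc3)c2n1CC(=O)O` differs from compound 1 by hydrogen in place of fluoro on an aromatic carbon. With no measured step of this kind in the series, no change beyond the scatter is expected in this assay; the expected step of a 1.1-fold lower number from compound 1 to compound 4 (0.05 log units; within the scatter) is essentially flat. Compound 4 is therefore estimated at 0.45 10^-6 cm/s, with a range of 0.15 10^-6 cm/s to 1.3 10^-6 cm/s.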

Compound 4, apparent permeability: 2.6 10^-6 cm/s
Compound 4: middle estimate off by 5.8-fold (0.76 log units), on the low side, outside the stated range (above it).
By their numbers in this assay, from the lowest: compound 1; then compound 4; then compound 2. At a limit, below all of these: compound 3.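

Within the data shown here, the first one-place step reads, in this assay, a 5.2-fold higher number from compound 1 to compound 4 (0.72 log units; beyond the scatter), so this aromatic carbon, para to a fluoro group on the 2,3,5,6-tetrafluorophenyl tail, is not silent in this read-out. Removing this single fluoro is enough to move the number beyond the scatter. Nothing measured here bears on why the number moves.

As far as these compounds go, whether a methoxy group or a nitrile at this carbon would move the number in the same direction remains open. So does whether removing a fluoro from another carbon of this ring gives a similar step.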